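The compounds below may be only part of what the source reports. "The series", "measured", "known", "first", "only" and "open" are said of these compounds alone.

Working notes on the series in an ADME assay on BJ cells (Homo sapiens) for cytotoxicity, read by luminescence, with a stated time of 72 h; a higher number here means that more compound is needed for the effect, a lower number that less compound is needed. Compound 1 `CCOC(=O)c1c(-c2cccc(OCC(C)C)c2)[nH]c2cc(OC)ccc2c1=O` is the reference point. In this assay compound 1 gives > 21500 nM, which is a limit of the assay and not a number. Compound 2 `CCOC(=O)c1c(-c2cccc(OCc3ccccc3)c2)[nH]c2cc(OC)ccc2c1=O` is the benzyloxy analogue; in this assay compound 2 gives > 21500 nM, again a limit. Compound 3 `CCOC(=O)c1c(-c2cccc(F)c2)[nH]c2cc(OC)ccc2c1=O` carries fluoro at the same aromatic carbon; in this assay compound 3 gives > 21500 nM, also a limit. For the measured compounds named here, because of the limit of > 21500 nM in this assay, at which 3 of the 3 values shown sit, none of the measured steps can be sized: a step that the two limits leave unreadable from compound 1 to compound 2, a step that the two limits leave unreadable from compound 1 to compound 3 and a step that the two limits leave unreadable from compound 2 to compound 3 are all unreadable, so compound 1 stands at the limit together with the other two and no direction or size of change among them is known.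

Compound 4 `CCOC(=O)c1c(-c2cccc(NC(C)=O)c2)[nH]c2cc(OC)ccc2c1=O` is the next member. It differs from compound 1 by acetamido in place of isobutoxy on an aromatic carbon. Going by the values given here, the steps that bear on this change are the ones from compound 1 to compound 2 and from compound 1 to compound 3, which alter the same aromatic carbon, but their sizes are not readable, so they give no expectation beyond a repeat of the limit. Three substituents of differing character at this position all left the value at the limit.

Compound 4 is therefore expected to give 30000 nM in this assay, with a range from 15000 nM to 80000 nM. The expected step is a step that the limit leaves unreadable from compound 1 to compound 4, most likely again reported only as a limit.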

Compound 4, half-maximal effective concentration: > 21500 nM
Compound 4 ended at the assay's limit; the forecaster's own chance of this, stated with the estimate: 85%; the middle value does not contradict the limit.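

In this assay compound 4 gives > 21500 nM, a limit of the assay and not a number. The steps joining compound 4 to compounds 1, 2 and 3 cannot be read because all four compounds stand at the same limit: the limit of > 21500 nM in this assay, at which 4 of the 4 values shown sit.

The compounds shown leave open whether any group at this aromatic carbon gives a measurable value in this assay.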